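This account rests on a few compounds, and the source may have more. Where it says the series, first, only, none or still open, it means among the compounds named here.

Measured so far:
Compound 1 `O=C(c1ccccc1F)N1CC[C@H]1c1nc(-c2cccc(F)c2)no1` gives 920 nM in an assay on HEK293 cells for negative allosteric modulation of metabotropic glutamate receptor 5 (Homo sapiens), read by FLIPR; on this read-out lower numbers stand for stronger inhibition and higher numbers for weaker inhibition.
Compound 2 `CC1CCCC(C(=O)N2CC(c3nc(-c4cccc(Cl)c4)no3)C2)C1` reaches only the assay limit, > 10000 nM, in this assay.
Compound 3 `O=C(N1CCC(F)CC1)N1CC(c2nc(-c3cccc(Cl)c3)no2)C1` likewise reaches only the assay limit, > 10000 nM, in this assay.

Compound 3 thus stands at the limit of this assay, and two of the three values shown sit there (the limit of > 10000 nM in this assay, at which 2 of the 3 values shown sit). Within the data shown here, the one measured step in this part of the series, a step that the two limits leave unreadable from compound 2 to compound 3, is unreadable because both of its ends are limits. Compound 4 `O=C(C1CCCO1)N1CC(c2nc(-c3cccc(Cl)c3)no2)C1` differs from compound 3 by oxolan-2-yl in place of 4-fluoropiperidin-1-yl on a carbonyl carbon. Among the measured compounds shown here, no measured step shows how this change acts, and compound 1 offers no comparable step. Compound 4 is therefore expected to remain near the limit. The step of a number no higher from compound 3 to compound 4 (the limit leaves the size open) is estimated as none beyond the scatter. The value for compound 4 is estimated at 10000 nM, with a range from 3000 nM to 30000 nM.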

Compound 4, half-maximal inhibitory concentration: 890 nM
Estimate against measurement, compound 4: 11-fold (1.05 log units) above; the whole stated range lies above it.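

Oxolan-2-yl in place of 4-fluoropiperidin-1-yl on the carbonyl carbon gives an at least 11-fold lower number from compound 3 to compound 4 (1.05 log units; beyond the scatter) in this assay. In place of 3-methylcyclohexyl, the same group gives an at least 11-fold lower number from compound 2 to compound 4 (1.05 log units; beyond the scatter) and so shows that this position responds to the group it carries, which the unreadable step between the two earlier limits could not show. On these data alone, both steps start from a limit, so their full size stays open: the limit of > 10000 nM in this assay, at which 2 of the 4 values shown sit.

As far as these compounds go, it remains open whether the ring oxygen of oxolan-2-yl or the smaller ring matters. Cyclopentyl or a methoxymethyl chain on the same carbonyl carbon would separate the two.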